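Phenyl for Cyclopentyl on the Amide of Compound 3

The source may report more compounds than this note shows. Statements on the series, on what has been measured and on what is new or still open speak of the compounds shown alone.

Measured so far in an assay on CHO-K1 cells for displacement of a labelled ligand from prostaglandin E2 receptor EP1 subtype (Homo sapiens); on this read-out higher numbers stand for weaker inhibition and lower numbers for stronger inhibition:
Compound 1 `Cc1cc(C(=O)Nc2ccc(F)cc2)nn1Cc1cc(Cl)ccc1OCc1ccccc1` gives 79.4 nM.
Compound 2 `Cc1cc(C(=O)Nc2c(F)cccc2F)nn1Cc1cc(Cl)ccc1OCc1ccccc1` gives 10 nM.
Compound 3 `Cc1cc(NC(=O)C2CCCC2)nn1Cc1cc(Cl)ccc1OCc1ccccc1` gives 15.9 nM.

Compound 3 stands second highest of the three numbers: a 1.6-fold higher number from compound 2 to compound 3 (0.20 log units; within the scatter), whereas a 5.0-fold lower number from compound 1 to compound 3 (0.70 log units; beyond the scatter). Compound 4 `Cc1cc(NC(=O)c2ccccc2)nn1Cc1cc(Cl)ccc1OCc1ccccc1` differs from compound 3 in one place: phenyl in place of cyclopentyl on a carbonyl carbon. Among the compounds with values here, no measured step exchanges a cyclopentyl for a phenyl; the two measured steps change the group on the amide-type nitrogen or replace the whole amide-bearing group, so none bears directly on this change. The expectation for compound 4 therefore rests on compound 3 alone, and the step is expected to stay small, a 1.3-fold higher number from compound 3 to compound 4 (0.10 log units; within the scatter), with a wide range in either direction. Compound 4 is thus estimated at 20 nM, between 5 nM and 80 nM.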

Compound 4, half-maximal inhibitory concentration: 15.9 nM
The estimate for compound 4 lay 1.3-fold (0.10 log units) above the measured number; low and high end bracket the measured number.
By their numbers in this assay, from the lowest: compounds 2, 3 and 4 (each within the scatter of the next); then compound 1.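

In this assay, an aromatic phenyl on this carbonyl carbon reads the same as the non-aromatic cyclopentyl (no change at the digits printed from compound 3 to compound 4 (within the scatter)), so this position tolerates both rings. The benzamido group of compound 4 also stays level with the (2,6-difluorophenyl)carbamoyl group (a 1.6-fold higher number from compound 2 to compound 4 (0.20 log units; within the scatter)) and keeps the advantage over the (4-fluorophenyl)carbamoyl group (a 5.0-fold lower number from compound 1 to compound 4 (0.70 log units; beyond the scatter)). Nothing measured here accounts for these results. Still open, on these data alone, is whether a ring is needed at all on this carbonyl carbon, as a methyl or a longer chain would show. Also open, as far as these compounds go, is how a pyridine ring or a fluorine on the phenyl would read.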